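Z to E on a dimethyl-substituted stilbene analogue

The source may hold more compounds than are shown below. What is called first, only, known or untested is meant among the compounds shown, and "the series" means these compounds.

In a functional assay on A549 cells (Homo sapiens) for cytotoxicity (on this read-out higher numbers stand for weaker inhibition and lower numbers for stronger inhibition), compound 1 `COc1cc(/C=C\c2ccc3cccnc3c2)cc(OC)c1OC` gives 158 nM. Compound 2 `COc1cc(/C=C\c2ccc3nc(C)c(C)nc3c2)cc(OC)c1OC` gives > 15800 nM, which is a limit of the assay and not a number. Compound 3 `COc1cc(/C=C/c2ccc3nc(C)c(C)nc3c2)cc(OC)c1OC` has the same atoms and bonds as compound 2 and differs only in configuration as drawn: the two compounds have the same atoms and bonds and differ only in configuration as drawn: 1 of 1 stereo elements differ; a double bond is drawn Z in compound 2 and E in compound 3. The double bond is drawn Z in compound 2 and E in compound 3. Going by the values given here, no measured pair isolates such a change, so nothing beyond the scatter is expected: the estimated step that the limit leaves unreadable from compound 2 to compound 3 in this assay stays small. The estimate for compound 3 is 16000 nM, with an expected range of 6000 nM to 40000 nM.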

Compound 3, half-maximal inhibitory concentration: > 15800 nM
Compound 3: only a limit was reported; the forecaster's own chance of this, stated with the estimate: 75%; the middle value is on the limit's open side.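

No step can be read from compound 2 to compound 3, as both values are limits of the assay. What the compounds shown leave open is whether drawing the double bond Z or E changes cytotoxicity at all.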